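The source may hold more compounds than are shown below. What is called first, only, known or untested is meant among the compounds shown, and "the series" means these compounds.

In a functional assay on HeLa cells (Homo sapiens) for inhibition, read by sulforhodamine B assay (on this read-out higher numbers stand for weaker inhibition and lower numbers for stronger inhibition), the measured values are:
- compound 1 `Cc1ccc(NC2=CC(=O)c3c(nc4n3[C@H]3OC[C@@H](O)[C@H]3OC4)C2=O)cc1C`: 4320 nM
- compound 2 `CCOc1ccc(NC2=CC(=O)c3c(nc4n3[C@H]3OC[C@@H](O)[C@H]3OC4)C2=O)cc1`: 14400 nM
- compound 3 `O=C1C(NC2CCCCC2)=CC(=O)c2c1nc1n2[C@H]2OC[C@@H](O)[C@H]2OC1`: > 16000 nM as a limit

For compound 3 the reading > 16000 nM is a limit of the assay and not a number. The change to compound 4 `CCOc1ccccc1NC1=CC(=O)c2c(nc3n2[C@H]2OC[C@@H](O)[C@H]2OC3)C1=O` is 2-ethoxyphenyl in place of cyclohexyl on an amine nitrogen and puts 2-ethoxyphenyl in place of cyclohexyl on an amine nitrogen. Within the data shown here, two measured steps bear on it: an at least 3.7-fold higher number from compound 1 to compound 3 (0.56 log units; beyond the scatter) and an at least 1.1-fold higher number from compound 2 to compound 3 (0.04 log units; that floor lies within the scatter), both with cyclohexyl entering. The step of a 3.3-fold higher number from compound 1 to compound 2 (0.52 log units; beyond the scatter) shows that the choice of aryl group matters too. Compound 4 shares an ethoxyphenyl with compound 2 at 14400 nM and so a modest move to a lower number is expected. Expected in this assay is an at least 1.6-fold lower number from compound 3 to compound 4 (0.20 log units; that floor lies within the scatter) as the step, though a second limit remains possible. For compound 4 the estimated value is 10000 nM with an expected range from 4500 nM to 22000 nM.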

Compound 4, half-maximal inhibitory concentration: 8300 nM
The estimate for compound 4 lay 1.2-fold (0.08 log units) above the measured number; low and high end bracket the measured number.
By their numbers in this assay, from the lowest: compounds 1, 4 and 2 (each within the scatter of the next, the first and the last beyond it). At a limit, above all of these: compound 3.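

In this assay, the reading for compound 3 is a limit of the assay and not a number: the limit of > 16000 nM in this assay, at which 1 of the 4 values shown sits.

Putting 2-ethoxyphenyl in place of cyclohexyl on the amine nitrogen gives an at least 1.9-fold lower number from compound 3 to compound 4 (0.28 log units; that floor lies within the scatter), so this aryl group returns a measurable number, though that floor does not establish a real gain. Among the aryl groups, the steps read a 1.7-fold lower number from compound 2 to compound 4 (0.24 log units; within the scatter) and a 1.9-fold higher number from compound 1 to compound 4 (0.28 log units; within the scatter), so 2-ethoxyphenyl is not separated from 4-ethoxyphenyl or 3,4-dimethylphenyl.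

Open, going by these compounds, is what an amine or a carboxylic acid on the phenyl ring, or a longer chain in place of ethoxy, would give in this assay.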